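The source may report more compounds than this note shows. Statements on the series, on what has been measured and on what is new or still open speak of the compounds shown alone.

In a functional assay on MDA-MB-231 cells (Homo sapiens) for inhibition, with a stated time of 72 h (on this read-out higher numbers stand for weaker inhibition and lower numbers for stronger inhibition), three compounds have been measured so far.

Compound 1 `COc1ccc(NC(=O)Nc2nc(Sc3c[nH]c4ccccc34)cc(N3CCCCC3)n2)cc1` gives 7260 nM
Compound 2 `O=C(Nc1ccccc1)Nc1nc(Nc2ccccc2)cc(Sc2c[nH]c3ccccc23)n1` gives 35900 nM
Compound 3 `O=C(Nc1ccc(Cl)cc1)Nc1nc(Sc2c[nH]c3ccccc23)cc(N2CCCCC2)n1` gives 10100 nM

Compound 3 lies within the scatter of compound 1. Compound 2 shows a higher number than compound 3, and that gap lies beyond the scatter.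

Compound 4 `O=C(Nc1ccccc1)Nc1nc(Sc2c[nH]c3ccccc23)cc(N2CCCCC2)n1` has not yet been measured. The change from compound 3 is hydrogen in place of chloro on an aromatic carbon and it places hydrogen in place of chloro on an aromatic carbon, turning 4-chlorophenyl to phenyl.

For the measured compounds named here, only one measured step touches this same place, and it swaps chloro in place of methoxy: a 1.4-fold higher number from compound 1 to compound 3 (0.14 log units; within the scatter) and so stays within the scatter. Going by the values given here, no measured step shows hydrogen entering there. Among the compounds with values here, compound 4 shares its phenyl with compound 2 at 35900 nM but differs from it elsewhere on the shared core, so that pair offers no clean step. On the evidence of the step to compound 3, no change beyond the scatter is expected in this assay and no direction can be favoured.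

The expected change is a 1.0-fold lower number from compound 3 to compound 4 (0.00 log units; within the scatter) as estimated here. For compound 4 the estimated value is 10000 nM with an expected range from 5000 nM to 21000 nM in this read-out.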

Compound 4, half-maximal inhibitory concentration: 8130 nM
Beside the measured number, compound 4's estimate is 1.2-fold (0.09 log units) above it; measured number inside the range.
By their numbers in this assay, from the lowest: compounds 1, 4 and 3 (each within the scatter of the next); then compound 2.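

In this assay, for the compounds shown here, 4-chlorophenyl to phenyl gives a 1.2-fold lower number from compound 3 to compound 4 (0.09 log units; within the scatter) and hydrogen in place of methoxy gives a 1.1-fold higher number from compound 1 to compound 4 (0.05 log units; within the scatter), so with hydrogen, chloro and methoxy now all read at this place, no step among compound 1, compound 3 and compound 4 leaves the scatter. Compound 4 also gives the first clean step at the other varied place on the shared core, where piperidin-1-yl in place of anilino gives a 4.4-fold lower number from compound 2 to compound 4 (0.65 log units; beyond the scatter) and so, among these compounds, the only step beyond the scatter falls there and not on the phenyl ring. Nothing available here accounts for either outcome.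

From the compounds shown here alone, what remains open is whether a carboxylic acid or a dimethylamino group at the place held by chloro and methoxy would stay as close to hydrogen as those two groups do. Going by these compounds, it is equally open whether a morpholin-4-yl or a piperazin-1-yl group in place of piperidin-1-yl would keep the number near that of compound 4 or move it toward that of compound 2.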